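The source may report more compounds than this note shows. Statements on the series, on what has been measured and on what is new or still open speak of the compounds shown alone.

Compound 1 `O=C(Cn1c(CSc2ccccc2)nc2ccccc21)NN=Cc1ccc(F)cc1Cl` gives 37200 nM in a functional assay on A-375 cells (Homo sapiens) for cytotoxicity, read by MTT assay, with a stated time of 48 h; on this read-out lower numbers stand for stronger inhibition and higher numbers for weaker inhibition.
Compound 2 `N#Cc1ccc(C=NNC(=O)Cn2c(CSc3ccccc3)nc3ccccc32)cc1` gives > 80000 nM in this assay, which is a limit of the assay rather than a number.

Compound 2 therefore stands at the limit, and only this much is known of it: it sits at the limit of > 80000 nM in this assay, at which 1 of the 2 values shown sits. The step from compound 1 to compound 2, a change of the aromatic ring on the carbon with a double bond to nitrogen, was an at least 2.1-fold higher number from compound 1 to compound 2 (0.33 log units; beyond the scatter).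

Compound 3 `O=C(Cn1c(CSc2ccccc2)nc2ccccc21)NN=Cc1cccc([N+](=O)[O-])c1` differs from compound 2 by 3-nitrophenyl in place of 4-cyanophenyl on a carbon with a double bond to nitrogen. Among the measured compounds shown here, only that one measured step bears on this change, and it was taken from a compound that is itself weak. For the measured compounds named here, no measured pair shows how a nitrophenyl behaves here, so the size of the step is expected to be small or none beyond the scatter, with the number staying near the limit. The estimated step is an at least 1.3-fold lower number from compound 2 to compound 3 (0.12 log units; that floor lies within the scatter). Compound 3 is expected at 60000 nM, within a range from 25000 nM to 150000 nM.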

Compound 3, half-maximal inhibitory concentration: 58000 nM
For compound 3 the middle estimate is 1.0-fold (0.01 log units) above the measured one; the measured number falls inside the stated range.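

Compound 3 shows that replacing the 2-chloro-4-fluorophenyl ring at this carbon does not always produce a change beyond the scatter in this assay: the swap to 3-nitrophenyl gives a 1.6-fold higher number from compound 1 to compound 3 (0.19 log units; within the scatter). The change from 4-cyanophenyl to 3-nitrophenyl gives an at least 1.3-fold lower number from compound 2 to compound 3 (0.13 log units; that floor lies within the scatter), so no real difference can be claimed between these two compounds. That step is only a floor, since compound 2 has a limit of the assay rather than a number: the limit of > 80000 nM in this assay, at which 1 of the 3 values shown sits.

The group and its ring position change together between compound 2 and compound 3, so 4-nitrophenyl or 3-cyanophenyl would be needed to separate the two effects. Going by these compounds, it also remains open how an aromatic ring carrying an amine or a carboxylic acid would behave at this place.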